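This account rests on a few compounds, and the source may have more. Where it says the series, first, only, none or still open, it means among the compounds named here.

In a toxicity assay on HepG2 2.2.15 cells (Homo sapiens) for cytotoxicity, read by CellTiter-Glo (on this read-out higher numbers stand for lower toxicity in this test and lower numbers for higher toxicity in this test), three compounds sharing one core have been measured. Compound 1 `N#CC1CC(=O)N(c2cnn3c2CN(C(=O)Nc2cc(F)c(F)c(F)c2)C(C2CC2)C3)C1` gives only a limit, > 200000 nM. Compound 2 `O=C1OC(c2ccccc2)CN1c1cnn2c1CN(C(=O)Nc1cc(F)c(F)c(F)c1)C(C1CC1)C2` gives 7410 nM and compound 3 `O=C1NC(c2ccccc2)CN1c1cnn2c1CN(C(=O)Nc1cc(F)c(F)c(F)c1)C(C1CC1)C2` gives 38500 nM, the higher of the two actual numbers, a gap described as a 5.2-fold higher number from compound 2 to compound 3 (0.72 log units; beyond the scatter).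

Compound 4 `Cc1cnc(C2CC(=O)N(c3cnn4c3CN(C(=O)Nc3cc(F)c(F)c(F)c3)C(C3CC3)C4)C2)s1` is unmeasured and differs from compound 3 by 4-(5-methyl-1,3-thiazol-2-yl)-2-oxopyrrolidin-1-yl in place of 2-oxo-4-phenylimidazolidin-1-yl on an aromatic carbon. Among the compounds with values here, no measured step makes this exact change. The nearest evidence is an at least 26-fold lower number from compound 1 to compound 2 (1.43 log units; beyond the scatter) and an at least 5.1-fold lower number from compound 1 to compound 3 (0.71 log units; beyond the scatter), where a group bearing an aromatic ring replaces 4-cyano-2-oxopyrrolidin-1-yl. Compound 4 also carries an aromatic ring, so it is expected to lie nearer compounds 2 and 3 than the limit of compound 1. No step beyond the scatter is therefore expected, although a 5.2-fold higher number from compound 2 to compound 3 (0.72 log units; beyond the scatter) warns that such an exchange can shift the number modestly. The expected change is a 1.5-fold lower number from compound 3 to compound 4 (0.19 log units; within the scatter). For compound 4 the estimate is 25000 nM, with an expected range from 7000 nM to 100000 nM.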

Compound 4, half-maximal cytotoxic concentration: 96200 nM
Estimate against measurement, compound 4: 3.8-fold (0.59 log units) below; the measured number falls inside the stated range.
By their numbers in this assay, from the lowest: compound 2; then compound 3; then compound 4. At a limit, above all of these: compound 1.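

In this assay, 4-(5-methyl-1,3-thiazol-2-yl)-2-oxopyrrolidin-1-yl gives the highest actual number yet at this place, with a 2.5-fold higher number from compound 3 to compound 4 (0.40 log units; beyond the scatter) and a 13-fold higher number from compound 2 to compound 4 (1.11 log units; beyond the scatter), so an aromatic ring in the group does not by itself bring the number down to the same level. Within the data shown here, the exchange of cyano for 5-methyl-1,3-thiazol-2-yl on a saturated ring carbon, with the 2-oxopyrrolidin-1-yl ring kept, gives an at least 2.0-fold lower number from compound 1 to compound 4 (0.31 log units; beyond the scatter), the first step here that alters only the substituent on that ring. The value of compound 1 is a limit and not a number: the limit of > 200000 nM in this assay, at which 1 of the 4 values shown sits.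

The compounds shown leave open how a phenyl group in place of 5-methyl-1,3-thiazol-2-yl on the 2-oxopyrrolidin-1-yl ring would read, so the ring that carries the substituent and the substituent itself cannot be told apart. They also leave open what an amine or a carboxylic acid on that saturated ring carbon would give.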